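Iodo in Place of Chloro: Expectation for Compound 4

This account rests on a few compounds, and the source may have more. Where it says the series, first, only, none or still open, it means among the compounds named here.

Compound 3 `COc1cc(CNC(=S)NCC(COC(=O)C(C)(C)C)Cc2ccc(C)c(C)c2)c(Cl)cc1O` gives 24.2 nM in an assay on CHO cells for displacement of a labelled ligand from transient receptor potential cation channel subfamily V member 1 (Rattus norvegicus); on this read-out higher numbers stand for weaker inhibition and lower numbers for stronger inhibition. Compound 1 `COc1cc(CNC(=S)NCC(COC(=O)C(C)(C)C)Cc2ccc(C)c(C)c2)cc(Cl)c1O` gives 30.9 nM and compound 2 `COc1cc(CNC(=S)NCC(COC(=O)C(C)(C)C)Cc2ccc(C)c(C)c2)cc(Br)c1O` gives 33.1 nM; the step of a 1.3-fold lower number from compound 1 to compound 3 (0.11 log units; within the scatter) and the step of a 1.4-fold lower number from compound 2 to compound 3 (0.14 log units; within the scatter) both lie within the scatter, so compound 3 is not separated from either of them by the numbers shown. Compound 4 `COc1cc(CNC(=S)NCC(COC(=O)C(C)(C)C)Cc2ccc(C)c(C)c2)c(I)cc1O` differs from compound 3 by iodo in place of chloro on an aromatic carbon. Going by the values given here, the only measured exchange of one halogen for another, a 1.1-fold higher number from compound 1 to compound 2 (0.03 log units; within the scatter), stayed within the scatter; the remaining steps move the halogen to another place rather than change its kind. On that basis no step beyond the scatter is expected, a 1.1-fold higher number from compound 3 to compound 4 (0.03 log units; within the scatter). Compound 4 is therefore estimated at 26 nM, with a range from 11 nM to 65 nM.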

Compound 4, inhibition constant: 18.9 nM
Estimate against measurement, compound 4: 1.4-fold (0.14 log units) above; the measured number falls inside the stated range.
By their numbers in this assay, from the lowest: compounds 4, 3, 1 and 2 (each within the scatter of the next).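

In this assay, iodo in place of chloro, on the carbon ortho to a large group and para to a methoxy group, stays within the scatter (a 1.3-fold lower number from compound 3 to compound 4 (0.11 log units; within the scatter)). An exchange of one halogen for another is thus seen at a second place on the ring, and the larger combined changes also stay within the scatter (a 1.8-fold lower number from compound 2 to compound 4 (0.24 log units; within the scatter); a 1.6-fold lower number from compound 1 to compound 4 (0.21 log units; within the scatter)). Nothing given here accounts for these small steps. The compounds shown leave open whether methyl, a nitrile or an amine at this place would stay within the scatter, and whether hydrogen there would.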